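This account rests on a few compounds, and the source may have more. Where it says the series, first, only, none or still open, it means among the compounds named here.

Measured so far:
compound 1, `CCCNNC(=O)c1ccc(CNC(=O)c2cnc3ccccc3c2)cc1` — an assay on isolated protein for inhibition of protein deacetylase HDAC6 (Homo sapiens), read by fluorescence, with a stated time of 2 h; a higher number here means a weaker inhibitor, a lower number a stronger inhibitor: > 10000 nM
compound 2, `CCCNNC(=O)c1ccc(CNC(=O)c2cc3ccccc3[nH]2)cc1` — this assay: > 10000 nM

Of the compounds shown here, two have been measured. In this assay compound 1 gives > 10000 nM, which is a limit of the assay and not a number. In this assay compound 2 gives > 10000 nM, again a limit and not a number. Compound 2 therefore stands at the limit of > 10000 nM in this assay, at which 2 of the 2 values shown sit. Among the compounds with values here, the two structures differ in more than one place, so no single step can be drawn between them; their two values show only that neither compound reached a measurable degree of inhibition.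

Compound 3 `CCCNNC(=O)c1ccc(CNC(=O)c2cc3cc(F)ccc3[nH]2)cc1` has not yet been measured. It differs from compound 2 by fluoro in place of hydrogen on an aromatic carbon. Within the data shown here, with compound 2 sitting at a limit, there is no measured step to lean on, and a change of one fluorine on the fused ring is small. The step in this assay is expected to be a step that the limit leaves unreadable from compound 2 to compound 3, that is, none beyond the scatter. Compound 3 is expected to give about 20000 nM in this assay, with a range from 5000 nM to 100000 nM, most likely again reported only as a limit.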

Compound 3, half-maximal inhibitory concentration: > 10000 nM
Compound 3: a limit, no number; the forecaster's own chance of this, stated with the estimate: 85%; the middle value lies beyond the limit too.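

In this assay compound 3 gives > 10000 nM, which is a limit of the assay and not a number. Compound 2 also stands at a limit, so no step can be read between compound 2 and compound 3 for fluoro in place of hydrogen on an aromatic carbon. The compounds shown leave open whether any of them has a measurable inhibitory strength, and how large the effect of this change is: the limit of > 10000 nM in this assay, at which 3 of the 3 values shown sit.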